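The source may report more compounds than this note shows. Statements on the series, on what has been measured and on what is new or still open speak of the compounds shown alone.

Working notes on the series. Compound 2 `COC(=O)C1(c2ccccc2)CC1CN1CCN(c2ccccn2)CC1` gives 1330 nM in an assay for displacement of a labelled ligand from Sigma non-opioid intracellular receptor 1 (Cavia porcellus); on this read-out higher numbers stand for weaker inhibition and lower numbers for stronger inhibition. Among the measured compounds shown here, compound 3 `COC(=O)C1(c2ccccc2)CC1CN1CCN(c2ncccn2)CC1` gives 3090 nM in this assay, and the step of a 2.3-fold higher number from compound 2 to compound 3 (0.37 log units; beyond the scatter) is the only change at one place that has been measured. Compound 1 `COC(=O)C1(c2ccc(C)cc2)CC1CN1CCC(Cc2ccccc2)CC1` differs from compounds 2 and 3 in several places. In this assay compound 1 gives 0.97 nM. Compound 3 therefore carries the highest number of the three; its nearest neighbour is compound 2, while compound 1 lies far lower.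

Compound 4 `COC(=O)C1(c2ccc(N)cc2)CC1CN1CCN(c2ncccn2)CC1` has not been measured. It differs from compound 3 in one place: amino in place of hydrogen on an aromatic carbon. For the measured compounds named here, no measured step touches this site. Compound 1 does carry a substituent on the same aromatic carbon, but its amine part is also different, so its value separates nothing about this site on its own. Going by the values given here, the one measured step concerned the amine nitrogen, not the aromatic ring, and so does not bear on the change at hand. Among the compounds with values here, with no precedent, the expected step of a 1.1-fold higher number from compound 3 to compound 4 (0.05 log units; within the scatter) in this assay is one that stays within the scatter. Compound 4 is accordingly estimated at 3500 nM in this assay, with a range from 1000 nM to 12000 nM.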

Compound 4, inhibition constant: > 10000 nM
Compound 4 gave a limit, no number; the forecaster's own chance of this, stated with the estimate: 5%; middle value at least 2.8-fold (0.45 log units) away from the limit.
By their numbers in this assay, from the lowest: compound 1; then compound 2; then compound 3. At a limit, above all of these: compound 4.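

The aromatic ring now has its first measured step: in this assay, phenyl to 4-aminophenyl gives an at least 3.2-fold higher number from compound 3 to compound 4 (0.51 log units; beyond the scatter), so this position is not indifferent to change and the amino group goes with weaker inhibition here. Compound 4 stands at a limit of the assay and not at a number, so the step fixes only a lower bound on the size of the change: the limit of > 10000 nM in this assay, at which 1 of the 4 values shown sits.
The substituent on the same aromatic carbon in compound 1 cannot be set against this step, as its amine part differs too, and the reading therefore holds only alongside the pyrimidin-2-yl group of compound 3.

From the compounds shown here alone, it remains open whether the change belongs to the amino group itself or would follow any group on this carbon, which a hydroxyl, a methoxy or a chlorine at the same place on compound 3 would help to separate. Also open, going by these compounds, is whether amino in place of hydrogen does the same alongside the amine part of compound 1, whose value of 0.97 nM would leave far more room for a step to be read in full.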